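The source may report more compounds than this note shows. Statements on the series, on what has been measured and on what is new or still open speak of the compounds shown alone.

Compound 1 `CS(=O)(=O)Nc1ccc(C#CCCN2CCC(Cc3ccccc3)CC2)cc1` was examined in an assay on isolated protein for binding affinity to Adrenergic receptor alpha-1 (Rattus norvegicus), read by radioligand binding (a higher number here means a weaker inhibitor, a lower number a stronger inhibitor), where compound 1 gives 1200 nM. Among the three compounds with numbers, compound 1 holds the second highest, but neither of its companions falls outside the usual scatter of repeated measurements. The closest is compound 3 `NCc1cccc(C#CCCN2CCC(Cc3ccccc3)CC2)c1`, which in this assay gives 800 nM; the furthest is compound 2 `CS(=O)(=O)Nc1ccc(C#CCN2CCC(Cc3ccccc3)CC2)cc1`, which in this assay gives 2200 nM. The three numbers therefore sit together within the range that repeat measurements normally cover, and no direction of change can be read from them.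

The next compound, compound 4 `NS(=O)(=O)c1ccc(C#CCCN2CCC(Cc3ccccc3)CC2)cc1`, keeps the shared core of compound 1 and differs from it in one place: sulfamoyl in place of methanesulfonamido on an aromatic carbon. For the measured compounds named here, no pair of measured compounds shows a change of this kind, so there is no measured step on which to lean. Given that the exchange is between two groups of like count of donors and acceptors on the same aromatic carbon, the step from compound 1 to compound 4 is expected to be small and within the scatter, in no firm direction, which is the meaning of a 1.3-fold higher number from compound 1 to compound 4 (0.10 log units; within the scatter). Compound 4 is accordingly estimated to give 1500 nM in this assay, within a range from 500 nM to 4500 nM.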

Compound 4, half-maximal inhibitory concentration: 1400 nM
For compound 4 the middle estimate is 1.1-fold (0.03 log units) above the measured one; the range from low to high includes it.
By their numbers in this assay, from the lowest: compounds 3, 1, 4 and 2 (each within the scatter of the next, the first and the last beyond it).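

In this assay, the exchange of methanesulfonamido for sulfamoyl on the aromatic carbon para to a large group gives a 1.2-fold higher number from compound 1 to compound 4 (0.07 log units; within the scatter), which is the only measured step at this position among the compounds shown. Its size lies within the scatter, so this assay does not separate these two groups, which match in their counts of hydrogen-bond donors and acceptors and carry no net charge, and the result shows that this one change, on the core of compound 1, leaves the number unmoved within what repeat measurements cover. No measured information bears on why the two groups read alike.

The compounds shown leave open whether a group less like these two, such as a carboxylic acid, a nitrile or a plain hydrogen on the same aromatic carbon, would move the number beyond the scatter. They also leave open whether the same exchange would give a step of similar size on the chain carried by compound 2, since a single step on a single core cannot show whether the finding holds elsewhere.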